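This account rests on a few compounds, and the source may have more. Where it says the series, first, only, none or still open, it means among the compounds named here.

Compound 1 `C#CCNC(=O)/C(C)=C(\C)c1ccc(Cl)cc1` gives 60 mg/kg in a toxicity assay on the whole organism (strain Icem-CET (SPF Caw)) for cytotoxicity, with Mus musculus as the target; on this read-out lower numbers stand for an effect already at smaller amounts and higher numbers for an effect only at larger amounts of compound. Compound 2 `C#CCNC(=O)/C(C)=C(\C)c1ccccc1` gives 150 mg/kg. Compound 3 `C#CCNC(=O)/C(C)=C(\C)c1ccc(F)cc1` gives 100 mg/kg.

Compound 2 stands at the upper end of these three numbers: the step of a 2.5-fold higher number from compound 1 to compound 2 (0.40 log units; beyond the scatter) lies beyond the scatter, whereas compound 3 sits within the scatter of compound 2, as the step of a 1.5-fold lower number from compound 2 to compound 3 (0.18 log units; within the scatter) shows. Compound 4 `C=CCNC(=O)/C(C)=C(\C)c1ccccc1` differs from compound 2 by vinyl in place of ethynyl on a saturated chain carbon bound to an amide-type nitrogen. Among the measured compounds shown here, none of the measured steps touches this part of the molecule; each of them changes only the substituent on the aromatic ring. For the measured compounds named here, no measured step therefore bears on this change, and no step beyond the scatter is expected in this assay. Compound 4 is accordingly estimated at 150 mg/kg, within 75 mg/kg to 300 mg/kg. The expected step is no change at the digits printed from compound 2 to compound 4 (within the scatter).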

Compound 4, dose for half-maximal effect: 130 mg/kg
For compound 4 the middle estimate is 1.2-fold (0.06 log units) above the measured one; the range from low to high includes it.
By their numbers in this assay, from the lowest: compounds 1, 3, 4 and 2 (each within the scatter of the next, the first and the last beyond it).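

Vinyl in place of ethynyl on the saturated chain carbon bound to the amide-type nitrogen gives a 1.2-fold lower number from compound 2 to compound 4 (0.06 log units; within the scatter) in this assay. Among the compounds shown here, this is the first reading at this position, and it shows that, with compound 2 as the parent, a double bond can stand in place of the triple bond without a step beyond the scatter. Nothing available explains this outcome.

As far as these compounds go, whether the same exchange holds with chloro or fluoro on the aromatic ring remains open. So does the effect of a saturated propyl chain, a longer chain or an amine here.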